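The compounds below may be only part of what the source reports. "The series", "measured", "known", "first", "only" and "open" are said of these compounds alone.

The measured compounds:
compound 1, `CCCCCCCCS(=O)(=O)Nc1cc(-c2ccccc2OC)ccc1C(=O)O`, in this assay 16100 nM
compound 2, `CCCCCCCCS(=O)(=O)Nc1cc(-c2ccc(OC)cc2)ccc1C(=O)O`, in this assay 13300 nM
compound 3, `CCCCCCCCS(=O)(=O)Nc1ccc(-c2ccccc2OC)cc1C(=O)O`, in this assay 27600 nM

All three were tested in an assay on mitochondria (strain BALB/c) for inhibition of glycerol-3-phosphate acyltransferase 1, mitochondrial (Mus musculus), read by scintillation counting, with a stated time of 10 min; on this read-out higher numbers stand for weaker inhibition and lower numbers for stronger inhibition. Compound 1 and compound 2 share one core; the change between them is 4-methoxyphenyl in place of 2-methoxyphenyl on an aromatic carbon, and it gave a 1.2-fold lower number from compound 1 to compound 2 (0.08 log units; within the scatter). Compound 3 carries a different core; how the core of compound 3 differs from the core of compound 1 is not broken down here. Compound 3 has the highest number of the three: its value lies within the scatter of compound 1 but beyond the scatter of compound 2.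

Compound 4, `CCCCCCCCS(=O)(=O)Nc1ccc(-c2ccc(OC)cc2)cc1C(=O)O`, has not yet been measured. It differs from compound 3 by 4-methoxyphenyl in place of 2-methoxyphenyl on an aromatic carbon. Among the measured compounds shown here, this is the same kind of change as the one from compound 1 to compound 2, but not the same: in compound 1 the group sits meta to a large group and para to a carboxy group, whereas in compound 3 it sits meta to a carboxy group and para to a large group.

For the measured compounds named here, the only guide to the expected step is the earlier one, and that one stayed within the scatter. The step from compound 3 to compound 4 is therefore expected to be a 1.2-fold lower number from compound 3 to compound 4 (0.08 log units; within the scatter), resting on a 1.2-fold lower number from compound 1 to compound 2 (0.08 log units; within the scatter). Compound 4 is estimated to give 23000 nM in this assay, with a range from 11000 nM to 48000 nM.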

Compound 4, half-maximal inhibitory concentration: 19500 nM
Beside the measured number, compound 4's estimate is 1.2-fold (0.07 log units) above it; the measured number falls inside the stated range.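

In this assay, putting 4-methoxyphenyl in place of 2-methoxyphenyl on the second core gave a 1.4-fold lower number from compound 3 to compound 4 (0.15 log units; within the scatter), a small step that does not separate the two compounds. Set beside the earlier case, the two cores show no measurable difference in how they respond to this change: the same change on two cores in this assay, a 1.2-fold lower number (0.08 log units; within the scatter) from compound 1 to compound 2 and a 1.4-fold lower number (0.15 log units; within the scatter) from compound 3 to compound 4, 1.2-fold (0.07 log units) apart, within the scatter of two such steps. This shows that, across these two cores, the swap from 2-methoxyphenyl to 4-methoxyphenyl carried over without any resolved departure, but it does not show that the swap has a real effect on either core, since each step on its own lies within the scatter, and two cores are too few to support a rule for the wider series.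

The compounds shown leave open whether any aryl group would move the number by more than the scatter, for instance 3-methoxyphenyl, an unsubstituted phenyl or a pyridine ring in the same place. They also leave open how a shorter or longer chain in place of the octyl chain, or a tetrazole or an ester in place of the carboxy group, would behave on either core.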